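This account rests on a few compounds, and the source may have more. Where it says the series, first, only, none or still open, it means among the compounds named here.

Compound 1, `CCCOC(=O)c1ccc(OCCCCCn2ccc(=O)[nH]c2=O)cc1`, was examined in an ADME assay on HEL cells (Homo sapiens) for cytotoxicity, read by microscopy; a higher number here means that more compound is tolerated, a lower number that less compound is tolerated. In this assay compound 1 gives >= 100000 nM, which is a limit of the assay rather than a measured number. Compound 1 thus stands at the limit of >= 100000 nM in this assay, at which 1 of the 2 values shown sits. Compound 2, `O=c1ccn(CCCCOc2ccc(Br)cc2)c(=O)[nH]1`, belongs to the same series. In this assay compound 2 gives 100000 nM. Compound 3, `Cc1ccc(OCCCCCn2ccc(=O)[nH]c2=O)cc1`, has not yet been measured in this assay. It differs from compound 1 in one place: methyl in place of propoxycarbonyl on an aromatic carbon. No measured step shows how such a change acts here, and compound 1 itself sits only at a limit, so no direction can be read from the numbers shown. The step in this assay from compound 1 to compound 3 is expected to be none beyond the scatter, a number no higher from compound 1 to compound 3 (the limit leaves the size open). Compound 3 is therefore expected to give 100000 nM, within a range from 50000 nM to 200000 nM, and most likely again only a limit.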

Compound 3, minimum cytotoxic concentration: 100000 nM
Compound 3: the middle estimate sits on the measured number at the digits printed; the range from low to high includes it.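

In this assay, methyl in place of propoxycarbonyl on an aromatic carbon, para to a large group, gives a number no higher from compound 1 to compound 3 (the limit leaves the size open). Within the data shown here, this is the first measured step at this position, and it gives compound 3 a measured number of 100000 nM, so the series now has a number with methyl at this place, a group with no hydrogen-bond acceptors, where the propoxycarbonyl group has 2. How far the change moves the number cannot be read, because compound 1 sits only at a limit: the limit of >= 100000 nM in this assay, at which 1 of the 3 values shown sits.

The compounds shown leave open whether an amine or a carboxylic acid on the same aromatic carbon would give a lower number in this assay. They also leave open what a longer chain on the shared core would do to that number.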